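This account rests on a few compounds, and the source may have more. Where it says the series, first, only, none or still open, it means among the compounds named here.

Compound 2 `COc1ccc(CN2C(=O)C(=O)c3cc(-c4cccc(OC)c4)ccc32)cc1` gives 1890 nM in a functional assay on HepG2 cells (Homo sapiens) for antiproliferative activity, read by MTT assay, with a stated time of 48 h (a higher number here means a weaker inhibitor, a lower number a stronger inhibitor), the highest of the two numbers shown. Compound 1 `COc1ccc(CN2C(=O)C(=O)c3cc(-c4ccc(OC)cc4)ccc32)cc1` gives 50 nM, and the step of a 38-fold higher number from compound 1 to compound 2 (1.58 log units; beyond the scatter) came with 3-methoxyphenyl in place of 4-methoxyphenyl. Compound 3 `COc1ccc(CN2C(=O)C(=O)c3cc(-c4cc(OC)cc(OC)c4)ccc32)cc1` differs from compound 2 by methoxy in place of hydrogen on an aromatic carbon, read one bond further out as 3-methoxyphenyl to 3,5-dimethoxyphenyl. No measured step adds a second methoxy group; the one step shown only moved a single one. Compound 3 is therefore expected to stay close to compound 2, with a step of a 1.3-fold higher number from compound 2 to compound 3 (0.12 log units; within the scatter) not beyond the scatter. For compound 3 the estimate is 2500 nM, within a range from 800 nM to 8000 nM.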

Compound 3, half-maximal inhibitory concentration: 1200 nM
Compound 3: the middle estimate sits 2.1-fold (0.32 log units) above what was measured; measured number inside the range.
By their numbers in this assay, from the lowest: compound 1; then compounds 3 and 2 (each within the scatter of the next).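

Adding a second methoxy group to the 3-methoxyphenyl ring does not move the result beyond the scatter, with a 1.6-fold lower number from compound 2 to compound 3 (0.20 log units; within the scatter). The 3,5-dimethoxyphenyl group also leaves the large gap to the 4-methoxyphenyl group in place, with a 24-fold higher number from compound 1 to compound 3 (1.38 log units; beyond the scatter), so this added methoxy does not recover the strength of compound 1. Nothing available here explains either result.

Still open, on these data alone, is whether a different group at this spot on the ring, such as an amine or a carboxylic acid, would behave like methoxy.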